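The compounds below may be only part of what the source reports. "The series", "measured", "known", "first", "only" and "open" are said of these compounds alone.

Of the compounds shown here, three have been measured in an assay on NIH3T3 cells for binding affinity to melatonin receptor type 1A (Homo sapiens); on this read-out higher numbers stand for weaker inhibition and lower numbers for stronger inhibition. Compound 1 `O=C(NC1CC1)N[C@H]1CCN(c2cccc3c2CCO3)C1` gives 21 nM. Compound 2 `O=C(NC1CC1)N[C@@H]1CCN(c2cccc3c2CCO3)C1` has the same atoms and bonds as compound 1 and differs only in the configuration at one saturated ring carbon. In this assay compound 2 gives 6.6 nM. Compound 3 `CCCC(=O)N[C@H]1CCN(c2cccc(OC)c2)C1` gives 3.7 nM.

Among the measured compounds shown here, the one step between compounds that differ in a single place is a 3.2-fold lower number from compound 1 to compound 2 (0.50 log units; beyond the scatter), a modest change that rests on (the fact that compounds 1 and 2 differ only in the configuration as drawn). Compound 2 therefore stands second highest of the three numbers: its nearest neighbour is compound 3, a gap within the scatter, and the furthest is compound 1.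

Compound 4 `CNC(=O)N[C@@H]1CCN(c2cccc3c2CCO3)C1` is the next compound to be measured in this assay. It differs from compound 2 in one place: methyl in place of cyclopropyl on an amide-type nitrogen. For the measured compounds named here, no measured step bears on this change, since the only measured step concerns a change in configuration rather than in the group carried by the urea nitrogen, and compound 3 differs from compound 2 in more than one place. A smaller group on that nitrogen is expected to cost little, so the step is estimated as a 1.5-fold higher number from compound 2 to compound 4 (0.18 log units; within the scatter), within or only just beyond the scatter. For compound 4 the expected value in this assay is 10 nM, with a range from 4 nM to 30 nM.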

Compound 4, inhibition constant: 2.2 nM
The estimate for compound 4 lay 4.5-fold (0.66 log units) above the measured number; the measured number lies below the stated range.
By their numbers in this assay, from the lowest: compounds 4, 3 and 2 (each within the scatter of the next, the first and the last beyond it); then compound 1.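

In this assay, the group on this amide-type nitrogen proves to matter, and removing the cyclopropyl ring does no harm: methyl in place of cyclopropyl gives a 3.0-fold lower number from compound 2 to compound 4 (0.48 log units; beyond the scatter) and so moves towards stronger inhibition. This is the first change shown in the group itself rather than in the configuration, and for this pair it shows that a group of one carbon serves better than a ring of three carbons at this place. The data shown offer no explanation for why the smaller group gives the lower number.

The compounds shown leave open how the number responds to other groups on this nitrogen, such as ethyl, isopropyl, a longer chain or a plain hydrogen, so one pair cannot show whether smaller is better in general or whether methyl is a special case. They also leave open whether the same exchange of cyclopropyl for methyl would give a similar step on the configuration drawn in compound 1, where the number starts out higher.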